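This account rests on a few compounds, and the source may have more. Where it says the series, first, only, none or still open, it means among the compounds named here.

Compound 1, `C=C(Br)C(=O)Nc1cccc(-c2cn3nc(-c4ccccc4)sc3n2)c1`, gives 900 nM in a functional assay on FM3A cells (Mus musculus) for inhibition, read by cell counting, with a stated time of 2 days; a higher number here means a weaker inhibitor, a lower number a stronger inhibitor.
Compound 2, `Nc1cccc(-c2cn3c(-c4ccc(Cl)cc4)csc3n2)c1`, gives 11000 nM in this assay.
Compound 3, `Nc1cccc(-c2cn3nc(-c4ccccc4)sc3n2)c1`, gives 14000 nM in this assay.

Compound 1 has the lowest number of the three, and its gaps to compound 2 and to compound 3 both lie beyond the scatter, so it is the strongest inhibitor measured here. Going by the values given here, the one single-point step available is the removal of the acyl group from the amide nitrogen, which gives a 16-fold higher number from compound 1 to compound 3 (1.19 log units; beyond the scatter); that step concerns the amide, not the distal phenyl ring.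

Compound 4, `C=C(Br)C(=O)Nc1cccc(-c2cn3nc(-c4ccc(OC)cc4)sc3n2)c1`, is the next compound. It differs from compound 1 only in this: methoxy in place of hydrogen on an aromatic carbon. Among the compounds with values here, no measured step changes that phenyl ring alone: compound 2 carries a chloro group there but also differs in the core arrangement, so its value shows only that it sits far above compound 1. With the acyl group kept, the change is expected to give no change at the digits printed from compound 1 to compound 4 (within the scatter), within the scatter. Compound 4 is therefore estimated at 900 nM, in a range from 300 nM to 2700 nM.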

Compound 4, half-maximal inhibitory concentration: 890 nM
Compound 4: middle estimate off by 1.0-fold (0.00 log units), on the high side, and the stated range covers the measured number.
By their numbers in this assay, from the lowest: compounds 4 and 1 (each within the scatter of the next); then compounds 2 and 3 (each within the scatter of the next).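

Going by these compounds alone, the change from phenyl to 4-methoxyphenyl gives a 1.0-fold lower number from compound 1 to compound 4 (0.00 log units; within the scatter) in this assay and is the first measured step at this ring with the shared core and the acyl group held fixed. A methoxy group at this position is therefore tolerated in place of hydrogen, and nothing here approaches the large step at the amide nitrogen, a 16-fold higher number from compound 1 to compound 3 (1.19 log units; beyond the scatter). No available evidence explains why the number stays level at this position.

A single group cannot show whether this carbon accepts any substituent, and an amine, a carboxylic acid or a longer chain such as butoxy could behave differently. Going by these compounds, it also remains open whether the same methoxy change would leave the number unmoved on compound 3, which lacks the acyl group.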